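The compounds below may be only part of what the source reports. "The series", "measured", "known", "first", "only" and "open" are said of these compounds alone.

Measured compounds in a physicochemical assay for lipophilicity, using the shake flask method, measured as octanol-water partition, at pH 7.4; a lower number here means a more polar compound, a higher number a more lipophilic compound:
compound 1 `CCN(CC)CCCCCCCCOc1ccc(/C=C/C(=O)Nc2ccccc2)cc1OC` gives 1.75
compound 2 `CCOC(=O)/C=C/c1ccc(OCCCCCCCCN(CC)CC)c(OC)c1` gives 1.98
compound 3 `COc1cc(/C=C/C(=O)O)ccc1OCCCCCCN1CCCCC1` gives 1.32

Compound 3 stands lowest of the three; compound 1 lies nearest to it and compound 2 furthest, both clearly higher. Going by the values given here, the only step measured between neighbours, a number 0.23 log units higher from compound 1 to compound 2 (within the scatter), concerns the carbonyl end of the molecule and has no bearing on the change now in question.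

Compound 4 `CCN(CC)CCCCCCCCOc1ccc(/C=C/C(=O)O)cc1OC` is the unmeasured member. Its change from compound 3 is 2-(diethylamino)ethyl in place of piperidin-1-yl on a saturated chain carbon, six bonds along the chain from an oxygen on an aromatic ring. Among the compounds with values here, compound 3 is the only acid among the measured compounds, and the basic end of the chain differs from that of compound 1 and compound 2 as well, so no measured pair isolates this change. The carbon count grows by one and the ring is opened; the acid and the remainder of the core stay as in compound 3.

The step of a number 0.23 log units higher from compound 3 to compound 4 (within the scatter) is expected to be small and upward, on the edge of the scatter. Compound 4 is therefore estimated at 1.55, in the range 1.1 to 2.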

Compound 4, partition coefficient: 1.51
Beside the measured number, compound 4's estimate is 0.04 log units above it; the range from low to high includes it.
By their numbers in this assay, from the lowest: compounds 3, 4, 1 and 2 (each within the scatter of the next, the first and the last beyond it).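

In this assay, 2-(diethylamino)ethyl in place of piperidin-1-yl, six bonds along the chain from an oxygen on an aromatic ring, gives a number 0.19 log units higher from compound 3 to compound 4 (within the scatter), so with the acid kept, these two chain ends cannot be told apart here. Going by these compounds alone, compound 4 also links the acid to the two carbonyl variants on the same chain: hydrogen in place of ethyl on an oxygen next to a carbonyl group gives a number 0.47 log units lower from compound 2 to compound 4 (beyond the scatter), the only new step beyond the scatter, whereas the acid set against the anilide gives a number 0.24 log units lower from compound 1 to compound 4 (within the scatter). No available evidence accounts for these steps.

Still open, from the compounds shown here alone, is whether a morpholine or pyrrolidine end would read like these two chain ends on the acid. A simple alkyl amide in place of the anilide is also untested by the compounds shown.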